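This account rests on a few compounds, and the source may have more. Where it says the series, first, only, none or still open, it means among the compounds named here.

Among the measured compounds shown here, in an ADME assay on microsomes from liver (Homo sapiens) for metabolic stability, read by LC-MS, with a stated time of 30 min, tested at 1 uM (a higher number here means that more of the compound is left, a lower number that less of the compound is left), compound 1 `O=C(NCc1ccc(S(=O)(=O)c2ccccc2)cc1)c1cc2ccncc2s1` gives 48%, the lower of the two numbers so far. Compound 2 `O=C(NCc1ccc(S(=O)(=O)c2cc(F)cc(F)c2)cc1)c1cc2cnccc2[nH]1`, which differs from compound 1 in more than one place, stands beyond the scatter from it. Compound 3 `O=C(NCc1ccc(S(=O)(=O)c2ccccc2)cc1)c1c[nH]c2ccncc12` keeps the rest of compound 1 and changes only the group on the carbonyl carbon: a group of 9 heavy atoms (7 carbon, 2 nitrogen; one five-membered aromatic ring with 1 hetero atom, one six-membered aromatic ring with 1 hetero atom) in place of a group of 9 heavy atoms (7 carbon, 1 nitrogen, 1 sulfur; one five-membered aromatic ring with 1 hetero atom, one six-membered aromatic ring with 1 hetero atom), on a carbonyl carbon. For the measured compounds named here, compound 2, whose group there likewise holds no sulfur, reaches 82%, and it is the only guide available. A rise beyond the scatter is expected, a number 20 percentage points higher from compound 1 to compound 3 (beyond the scatter). For compound 3 the estimated value is 68%, within a range of 50% to 85%.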

Compound 3, percent of the compound remaining: > 99%
Compound 3: only a limit was reported (the forecaster's own chance of this, stated with the estimate: 1%); middle value at least 31 percentage points away from the limit.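

Changing only the group on a carbonyl carbon, from the sulfur-containing group to the one with 2 nitrogen atoms, gives in this assay a number at least 51 percentage points higher from compound 1 to compound 3 (beyond the scatter). This single change at the position is enough for a large step. Compound 3 gives > 99%, which is a limit and not a number, so the full size of the step stays unknown: the limit of > 99% in this assay, at which 1 of the 3 values shown sits.

The compounds shown leave open which feature of the entering group goes with the step. From the compounds shown here alone, whether the value would hold with a methyl group on the nitrogen that carries hydrogen also remains open.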